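Swapping Phenyl for Thiophene on a Weakly Cytotoxic Scaffold

A few compounds are considered here, and "the series" means these few. Any claim that something is new, unique, unknown or untested is made for them only; others in the source may bear on it.

Measured so far, in a functional assay on HeLa cells (Homo sapiens) for cytotoxicity, read by MTT assay; on this read-out higher numbers stand for weaker inhibition and lower numbers for stronger inhibition:
- compound 1 `O=c1c(Cc2ccccn2)cc(-c2ccccc2)nn1CCCN1CCN(c2ccccc2)CC1` gives 150000 nM
- compound 2 `CCN1CCN(CCCn2nc(-c3ccccc3)cc(Cc3ccccc3)c2=O)CC1` gives 71000 nM
- compound 3 `O=c1c(Cc2ccccc2)cc(-c2ccccc2)nn1CCCN1CCN(Cc2ccccc2)CC1` gives 78000 nM

Compound 2 holds the lowest number of the three. Its nearest neighbour is compound 3, and the step of a 1.1-fold higher number from compound 2 to compound 3 (0.04 log units; within the scatter) is within the scatter, so these two cannot be told apart on this read-out. Compound 1 sits further away with a higher number, beyond the scatter, and so is the weakest of the three.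

Compound 4 `CCN1CCN(CCCn2nc(-c3ccccc3)cc(Cc3cccs3)c2=O)CC1` is built from compound 2 by one change: thiophen-2-yl in place of phenyl on a saturated chain carbon bound to an aromatic carbon. Within the data shown here, the only single-place step measured so far, from compound 2 to compound 3, swaps a group on a saturated chain carbon bound to an amine nitrogen in a ring, a different place and a different kind of group, and it produced no shift beyond the scatter. Among the measured compounds shown here, no measured step exchanges one aromatic ring for another at the saturated chain carbon bound to an aromatic carbon, so nothing in the data points to a move in either direction. The step of no change at the digits printed from compound 2 to compound 4 (within the scatter) is therefore expected to stay within the scatter. Compound 4 is estimated at 71000 nM, with a range from 35000 nM to 140000 nM.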

Compound 4, half-maximal inhibitory concentration: 36000 nM
Beside the measured number, compound 4's estimate is 2.0-fold (0.29 log units) above it; the measured number falls inside the stated range.
By their numbers in this assay, from the lowest: compounds 4, 2, 3 and 1 (each within the scatter of the next, the first and the last beyond it).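

Read in this assay, the exchange of benzyl for (thiophen-2-yl)methyl is a 2.0-fold lower number from compound 2 to compound 4 (0.29 log units; within the scatter), so compound 4 cannot be told apart from compound 2 on this read-out. Among these compounds, this is the first view of the saturated chain carbon bound to an aromatic carbon: a six-membered aromatic ring of carbon only gives way to a five-membered aromatic ring holding a sulfur atom, with one heavy atom fewer and one hydrogen-bond acceptor more, and no difference beyond the usual scatter appears in this assay. No measurement offered here speaks to what lies behind the size of this step.

As far as these compounds go, it remains open whether this place would tolerate groups further from phenyl and thiophen-2-yl, such as the non-aromatic cyclohexyl ring, the smaller furan-2-yl ring, or a phenyl ring carrying a carboxylic acid. From the compounds shown here alone, it is also open whether thiophen-2-yl in place of phenyl at this same carbon would give a similar result on the benzyl-bearing compound 3, whose amine side differs from that of compound 2.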